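The compounds below may be only part of what the source reports. "The series", "measured", "known", "first", "only" and "open" are said of these compounds alone.

Measured compounds in a functional assay on A-431 cells (Homo sapiens) for cytotoxicity, read by MTT assay, with a stated time of 24 h; on this read-out lower numbers stand for stronger inhibition and higher numbers for weaker inhibition:

compound 1 `COc1ccc(/C=C\C(=O)O)c(OCc2cn(-c3ccccc3C(=O)N3CCC(O)C3)nn2)c1CC=C(C)C` gives 31500 nM
compound 2 `COc1ccc(/C=C\C(=O)O)c(OCc2cn(-c3cccnc3Cl)nn2)c1CC=C(C)C` gives 32600 nM
compound 3 `COc1ccc(/C=C\C(=O)O)c(OCc2cn(-c3nc4ccccc4s3)nn2)c1CC=C(C)C` gives 20800 nM

All three share the same core and differ only in the aromatic group on the triazole nitrogen. Compound 3 gives the lowest number of the three, but its gaps to compound 1 and to compound 2 both stay within the scatter, so none of the three is set apart on these numbers.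

The next compound, compound 4 `COc1ccc(/C=C\C(=O)O)c(OCc2cn(-c3ccccc3C#N)nn2)c1CC=C(C)C`, carries the change (2-cyanophenyl in place of 1,3-benzothiazol-2-yl on an aromatic nitrogen). Going by the values given here, the one measured step that bears on it is the same kind of swap at the same nitrogen: a 1.6-fold lower number from compound 2 to compound 3 (0.20 log units; within the scatter). Compound 1, with a further aromatic variant at that position, gives 31500 nM, again within the scatter of compound 3. Three different aromatic groups at this nitrogen thus give numbers that cannot be told apart, and nothing in the data singles out the nitrile-bearing ring.

For compound 4 in this assay no step beyond the scatter is expected; the estimated step of a 1.3-fold higher number from compound 3 to compound 4 (0.13 log units; within the scatter) is small. Compound 4 is therefore expected to give about 28000 nM, with a range from 14000 nM to 56000 nM.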

Compound 4, half-maximal inhibitory concentration: 10300 nM
The estimate for compound 4 lay 2.7-fold (0.43 log units) above the measured number, and the stated range ends above it.
By their numbers in this assay, from the lowest: compound 4; then compounds 3, 1 and 2 (each within the scatter of the next).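

In this assay, going by these compounds alone, the group on the aromatic nitrogen of the five-membered ring now separates the compounds, which the earlier steps within the scatter could not show: the 2-cyanophenyl group stands apart from all three other groups (a 2.0-fold lower number from compound 3 to compound 4 (0.31 log units; beyond the scatter); a 3.2-fold lower number from compound 2 to compound 4 (0.50 log units; beyond the scatter); a 3.1-fold lower number from compound 1 to compound 4 (0.49 log units; beyond the scatter)), and each step is modest and beyond the scatter. The last of these steps keeps the six-membered aromatic ring of carbon only and exchanges just the group on an aromatic carbon, so the change from (3-hydroxypyrrolidin-1-yl)carbonyl to cyano is enough on its own to give a step beyond the scatter, with no change of ring needed. No measurement at hand explains the difference between these groups.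

Whether the nitrile itself matters remains open, since the compounds shown do not include an unsubstituted phenyl group or a ring with an aminomethyl group or a methyl ester in place of the nitrile. From the compounds shown here alone, it is also open whether the step from the 2-cyanophenyl group would carry over to a core with a methyl ester in place of the carboxylic acid, as all four compounds share the same core.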